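The compounds below may be only part of what the source reports. "The series", "measured", "known", "first", "only" and "open" are said of these compounds alone.

Measured in a functional assay on HeLa cells (Homo sapiens) for inhibition, read by MTT assay, with a stated time of 72 h; on this read-out lower numbers stand for stronger inhibition and higher numbers for weaker inhibition:
- compound 1 `C=C(Br)C(=O)Nc1cccc(/C=C/C(=O)Nc2ccc(Cl)cc2)c1`: 2800 nM
- compound 2 `C=C(Br)C(=O)Nc1cccc(/C=C/C(=O)Nc2ccc(C)cc2)c1`: 1500 nM
- compound 3 `C=C(Br)C(=O)Nc1cccc(/C=C/C(=O)Nc2ccc(OC)cc2)c1`: 790 nM

Compound 3 sits at the low end of these numbers, with a 1.9-fold lower number from compound 2 to compound 3 (0.28 log units; within the scatter) and a 3.5-fold lower number from compound 1 to compound 3 (0.55 log units; beyond the scatter). Compound 4 `C=C(Br)C(=O)Nc1cccc(/C=C/C(=O)Nc2ccc(OC(F)(F)F)cc2)c1` carries trifluoromethyl in place of methyl on an oxygen on an aromatic ring. Among the compounds with values here, no measured step makes this exact change. The closest guides are swaps of other groups at the same place, and these stayed modest, the largest being a 3.5-fold lower number from compound 1 to compound 3 (0.55 log units; beyond the scatter). Within the data shown here, compound 1, the only measured compound with a halogen in that group, gives 2800 nM, so a modest rise is a reasonable expectation. The expected change is a 2.4-fold higher number from compound 3 to compound 4 (0.38 log units; beyond the scatter). Compound 4 is estimated at 1900 nM, with an expected range from 700 nM to 5000 nM.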

Compound 4, half-maximal inhibitory concentration: 29000 nM
Compound 4: the middle estimate sits 15-fold (1.18 log units) below what was measured; measured number above the stated range.
By their numbers in this assay, from the lowest: compounds 3, 2 and 1 (each within the scatter of the next, the first and the last beyond it); then compound 4.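

In this assay this position proves far less forgiving than the earlier swaps suggested: replacing methyl with trifluoromethyl on the oxygen gives a 37-fold higher number from compound 3 to compound 4 (1.56 log units; beyond the scatter) and outweighs every change among chloro, methyl and methoxy. Compound 4 also stands well apart from the other two compounds, with a 19-fold higher number from compound 2 to compound 4 (1.29 log units; beyond the scatter) and a 10-fold higher number from compound 1 to compound 4 (1.02 log units; beyond the scatter) in the same direction. Nothing available here explains this loss.

Still open, going by these compounds, is how other groups would behave at this place. An ethoxy group, a hydroxyl or an amine could show whether the sharp rise is specific to trifluoromethoxy.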